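This account rests on a few compounds, and the source may have more. Where it says the series, first, only, none or still open, it means among the compounds named here.

Measured compounds:
compound 1 `Cc1ccc2nc(-c3ccccc3N(C)C)[nH]c(=O)c2c1` — 82.9%
compound 2 `Cc1ccc2nc(-c3cccc4ccccc34)[nH]c(=O)c2c1` — 4.1%

Of the compounds shown here, two have been measured in an assay on isolated protein for inhibition of DNA topoisomerase 1 (Homo sapiens), with a stated time of 30 min, tested at 100 uM; on this read-out lower numbers stand for a weaker effect and higher numbers for a stronger effect at the one concentration tested. Compound 1 reaches 82.9%, whereas compound 2 gives only 4.1%. Compound 2 therefore stands lowest of the two numbers, and its nearest neighbour, compound 1, lies a long way higher, a gap well beyond the scatter of this assay. Going by the values given here, no two measured compounds differ in a single place, so no measured step is available to guide the next move.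

Compound 3 `CCN(CC)c1ccc2nc(-c3cccc4ccccc34)[nH]c(=O)c2c1` is the compound still to be tested. It is obtained from compound 2 by one change: diethylamino in place of methyl on an aromatic carbon. The diethylamino group enters on the bicyclic part of the shared core, where compound 2 carries a methyl, not on the pendant ring.

Nothing measured speaks directly to this exchange. Compound 2 sits at the bottom of the range, so the room to fall is small, and a modest upward step is expected from compound 2 to compound 3, a number 15.9 percentage points higher from compound 2 to compound 3 (beyond the scatter), with a real chance of none beyond the scatter. Compound 3 is thus estimated at 20% in this assay, within a range of 2% to 55%.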

Compound 3, a percentage reported as inhibition, at one concentration (the size of the read-out at that concentration, not a potency): 90.4%
Compound 3: middle estimate off by 70.4 percentage points, on the low side, outside the stated range (above it).
By their numbers in this assay, from the lowest: compound 2; then compounds 1 and 3 (each within the scatter of the next).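

Exchanging methyl for diethylamino on this aromatic carbon of the shared core has a large effect in this assay, giving a number 86.3 percentage points higher from compound 2 to compound 3 (beyond the scatter) while the pendant ring stays unchanged. The earlier compounds shown here could not show this, as no two of them differed in a single place; the step now shows that the low reading of compound 2 is not set by its pendant ring alone, and that this position on the core can by itself carry the difference between a near-empty reading and a high one at the single concentration tested. No measurement available here accounts for the size of this step.

This single exchange leaves open whether the gain belongs to diethylamino specifically or would also appear with a smaller dimethylamino group, a cyclic amine such as pyrrolidine, or an ether such as methoxy on the same carbon. It also leaves open whether the same exchange would change the reading on a core bearing a different pendant ring, and how a reading at one concentration would translate into a potency.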